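This account rests on a few compounds, and the source may have more. Where it says the series, first, only, none or still open, it means among the compounds named here.

Working notes on the series. Compound 1 `Cc1ccc(C2CNC(=O)N2S(=O)(=O)c2ccccc2)cc1` and compound 2 `Cc1ccc(C2CNC(=O)N2S(=O)(=O)c2ccc(Cl)cc2)cc1` share one core; compound 3 `O=C1NCC(c2ccc(Cl)cc2)N1S(=O)(=O)c1ccc2c(c1)CCC2` carries another. In a functional assay on SK-MEL-2 cells (Homo sapiens) for cytotoxicity (on this read-out higher numbers stand for weaker inhibition and lower numbers for stronger inhibition), compound 1 gives 144000 nM, compound 2 gives 255000 nM and compound 3 gives 161000 nM. Within the first core the step of a 1.8-fold lower number from compound 2 to compound 1 (0.25 log units; within the scatter) corresponds to the change (hydrogen in place of chloro on an aromatic carbon). Compound 3 sits close to compound 1 and compound 2 in this assay; the difference between the two cores is not broken down here.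

Compound 4 `O=C1NCC(c2ccccc2)N1S(=O)(=O)c1ccc2c(c1)CCC2` is not yet measured. For the measured compounds named here, it differs from compound 3 by hydrogen in place of chloro on an aromatic carbon, which is the same change as the one from compound 2 to compound 1, made on the same place of the ring. The expectation for compound 4 in this assay therefore rests on compound 2 and compound 1 and their step of a 1.8-fold lower number from compound 2 to compound 1 (0.25 log units; within the scatter), taken onto compound 3: the step of a 1.6-fold lower number from compound 3 to compound 4 (0.21 log units; within the scatter) is estimated. Compound 4 is expected to give about 100000 nM, with a range from 50000 nM to 250000 nM in this assay.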

Compound 4, half-maximal inhibitory concentration: 39000 nM
Beside the measured number, compound 4's estimate is 2.6-fold (0.41 log units) above it, and the stated range ends above it.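

In this assay, hydrogen in place of chloro gives a 4.1-fold lower number from compound 3 to compound 4 (0.62 log units; beyond the scatter), and this step can be set beside the earlier one on the core of compound 1: the same change on two cores in this assay, a 1.8-fold lower number (0.25 log units; within the scatter) from compound 2 to compound 1 and a 4.1-fold lower number (0.62 log units; beyond the scatter) from compound 3 to compound 4, 2.3-fold (0.37 log units) apart, within the scatter of two such steps. For the compounds shown here, the two steps therefore cannot be told apart, and the data give no ground for saying that the size of this change depends on the core, although only the step on the core of compound 3 lies beyond the scatter by itself. With just two pairs, this shows neither a fixed size for the change nor that it would carry over to any further core in the series.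

The compounds shown leave open what other groups at the same place on the ring would do, such as methoxy, an amine or a carboxylic acid, as they show only chloro and hydrogen there. From the compounds shown here alone, it also remains open whether the step from 4-chlorophenyl to phenyl would hold in other cell lines.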